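This account rests on a few compounds, and the source may have more. Where it says the series, first, only, none or still open, it means among the compounds named here.

Compound 1 `c1ccc(-c2cn3ccnc3c(-c3ccc4ncn(C5CCCCC5)c4c3)n2)cc1` gives 36.8% in a functional assay on 786-0 cells (Homo sapiens) for inhibition, read by sulforhodamine B assay, with a stated time of 48 h, tested at 10 uM; a higher number here means more inhibition at the concentration tested (going by the name of the read-out), a lower number less inhibition.
Compound 2 `Clc1ccc(-c2cn3ccnc3c(-c3ccc4ncn(C5CCCCC5)c4c3)n2)cc1` gives 12.1% in this assay.
Compound 3 `Brc1ccc(-c2cn3ccnc3c(-c3ccc4ncn(C5CCCCC5)c4c3)n2)cc1` gives 18% in this assay.

Compound 1 stands highest of the three numbers in this assay; compound 3 comes nearest and compound 2 lies furthest away. The two measured changes on the phenyl ring both lowered the read-out beyond the scatter: a number 24.7 percentage points lower from compound 1 to compound 2 (beyond the scatter) and a number 18.8 percentage points lower from compound 1 to compound 3 (beyond the scatter). Between the two halogen compounds the gap is small, a number 5.9 percentage points higher from compound 2 to compound 3 (within the scatter), and lies within the scatter.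

Compound 4 `COc1ccccc1-c1cn2ccnc2c(-c2ccc3ncn(C4CCCCC4)c3c2)n1` differs from compound 1 by methoxy in place of hydrogen on an aromatic carbon. For the measured compounds named here, no measured step puts a methoxy on this ring, and both measured steps place their group at a different point of it, so they bear on the new change only loosely. They agree in direction, however: each added group lowered inhibition. A lower value for compound 4 is therefore expected, though with wide uncertainty, and the expected change is a number 11.8 percentage points lower from compound 1 to compound 4 (beyond the scatter). Compound 4 is estimated at 25%, within a range from 8% to 42%.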

Compound 4, a percentage reported as inhibition, at one concentration (the size of the read-out at that concentration, not a potency): 12.3%
For compound 4 the middle estimate is 12.7 percentage points above the measured one; the range from low to high includes it.
By their numbers in this assay, from the lowest: compounds 2, 4 and 3 (each within the scatter of the next); then compound 1.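

In this assay, the change from phenyl to 2-methoxyphenyl gives a number 24.5 percentage points lower from compound 1 to compound 4 (beyond the scatter), so a group ortho to a large group goes with lower inhibition, as the halogens in 4-chlorophenyl and 4-bromophenyl do. The 2-methoxyphenyl compound also sits level with both halogen compounds, with a number 5.7 percentage points lower from compound 3 to compound 4 (within the scatter) and a number 0.2 percentage points higher from compound 2 to compound 4 (within the scatter), so among these compounds neither the kind of group nor its place on the ring separates the substituted phenyl compounds. Nothing measured here explains the loss of inhibition.

On these data alone, it remains open whether any group on this ring can keep or raise the read-out of compound 1, for instance an amine or a carboxylic acid. As far as these compounds go, it is also open whether 4-methoxyphenyl would match 2-methoxyphenyl, which would separate the effect of the group from that of its place.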